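A few compounds are considered here, and "the series" means these few. Any claim that something is new, unique, unknown or untested is made for them only; others in the source may bear on it.

Measured compounds:
Compound 1 `NCc1csc(NC(=O)c2ncccn2)n1`: > 100 ug/mL
Compound 2 `CN(C)Cc1csc(NC(=O)c2cc(C(C)(C)C)nn2Cc2ccccc2)n1`: > 100 ug/mL

In a physicochemical assay for solubility, read by nephelometry, measured as kinetic solubility, at pH 2.0 (on this read-out higher numbers stand for higher solubility and lower numbers for lower solubility), compound 2 gives > 100 ug/mL as a limit of the assay, not a number. Compound 1 also gives > 100 ug/mL in this assay as a limit, not a number. The data so far therefore hold the limit of > 100 ug/mL in this assay, at which 2 of the 2 values shown sit, and no exact figure, and neither compound can be ranked against the other.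

Compound 3 (`CNCc1csc(NC(=O)c2cc(C(C)(C)C)nn2Cc2ccccc2)n1`) differs from compound 2 in one place (hydrogen in place of methyl on an amine nitrogen): hydrogen in place of methyl on an amine nitrogen, so that dimethylamino becomes methylamino. For the measured compounds named here, no measured pair shows what this change does. In this assay no step beyond the usual scatter is expected, and another limit is the likeliest report, because compound 2 gives > 100 ug/mL as a limit. The expected step that the limit leaves unreadable from compound 2 to compound 3 is therefore small. For compound 3 the estimate is 110 ug/mL with an expected range from 75 ug/mL to 160 ug/mL on this reading.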

Compound 3, solubility: 25 ug/mL
Estimate against measurement, compound 3: 4.4-fold (0.64 log units) above, and the stated range ends above it.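

In this assay, going from dimethylamino to methylamino comes with an at least 4.0-fold lower number from compound 2 to compound 3 (0.60 log units; beyond the scatter), so a change of a single carbon atom on this amine nitrogen can move the read-out by more than ordinary repeat-to-repeat variation. Compound 3 gives 25 ug/mL, the only exact figure among the compounds shown, and it gives this series its first real number on this read-out. The full size of the step remains unknown, because its starting point is a limit of the assay and not a number: the limit of > 100 ug/mL in this assay, at which 2 of the 3 values shown sit.

This single pair does not show why the number falls, or whether the same change would have a similar effect on another core, such as that of compound 1. It also leaves open how the read-out responds to other groups on this amine nitrogen, since an ethyl group or a 2-hydroxyethyl group in place of the methyl would test whether the result depends on the size or the kind of the group there.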